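Hydroxamic acid ring-position isomer in the bile acid receptor series

The compounds below may be only part of what the source reports. "The series", "measured", "known", "first", "only" and "open" are said of these compounds alone.

Measured so far:
- compound 1, `CN(Cc1cccc(C(=O)O)c1)c1ccc(OCc2c(-c3c(Cl)cccc3Cl)nsc2C2CC2)nc1C(F)(F)F`, in an assay on HEK293T cells for agonist activity at Bile acid receptor (Homo sapiens), read by a luciferase reporter and fluorescence (on this read-out lower numbers stand for an effect already at smaller amounts and higher numbers for an effect only at larger amounts of compound), compound 1 gives 270 nM
- compound 2, `CN(Cc1cccc(C(=O)NO)c1)c1ccc(OCc2c(-c3c(Cl)cccc3Cl)nsc2C2CC2)nc1C(F)(F)F`, in this assay compound 2 gives 1090 nM

Within the data shown here, compound 2 holds the higher of the two numbers measured in this assay; the only known step in the set is a 4.0-fold higher number from compound 1 to compound 2 (0.61 log units; beyond the scatter), and it separates the two compounds by more than the usual scatter.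

Compound 3, `CN(Cc1ccc(C(=O)NO)cc1)c1ccc(OCc2c(-c3c(Cl)cccc3Cl)nsc2C2CC2)nc1C(F)(F)F`, keeps every atom of compound 2 and changes only where the hydroxycarbamoyl group sits on the ring: 4-(hydroxycarbamoyl)phenyl in place of 3-(hydroxycarbamoyl)phenyl on a saturated chain carbon bound to a nitrogen on an aromatic ring.

Among the measured compounds shown here, no measured step bears directly on this change. For the measured compounds named here, the one known step, a 4.0-fold higher number from compound 1 to compound 2 (0.61 log units; beyond the scatter), concerns the exchange at the carbonyl carbon, not the position of the group on the ring, so it gives no guide to direction. Both measured compounds carry the substituent at the same ring position; nothing here shows what moving it does. The expectation for compound 3 is therefore a step of about a 1.1-fold lower number from compound 2 to compound 3 (0.04 log units; within the scatter), within the scatter, but with a wide range in either direction.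

The estimate for compound 3 in this assay is 1000 nM, expected to fall between 250 nM and 4000 nM.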

Compound 3, half-maximal effective concentration: > 30000 nM
Compound 3 ended at the assay's limit (the forecaster's own chance of this, stated with the estimate: 5%); middle value at least 30-fold (1.47 log units) away from the limit.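

In this assay compound 3 ends at the upper end of the range, and its value is a limit, not a number: the limit of > 30000 nM in this assay, at which 1 of the 3 values shown sits.

With the same atoms joined differently, 4-(hydroxycarbamoyl)phenyl in place of 3-(hydroxycarbamoyl)phenyl gives an at least 27-fold higher number from compound 2 to compound 3 (1.43 log units; beyond the scatter), so the ring position of this group matters in this series, and this step is larger than the exchange at the carbonyl carbon, a 4.0-fold higher number from compound 1 to compound 2 (0.61 log units; beyond the scatter). Measured against the carboxylic acid, the combined change reads an at least 110-fold higher number from compound 1 to compound 3 (2.04 log units; beyond the scatter), and of the two hydroxamic acids shown, only the one carrying 3-(hydroxycarbamoyl)phenyl gives a value inside the range of the assay.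

Still open, on these data alone, is whether a carboxylic acid in place of the hydroxycarbamoyl group in 4-(hydroxycarbamoyl)phenyl would reach the same limit, which would show whether the loss belongs to the ring position generally or only to this group there. Also open, as far as these compounds go, is whether a primary amide, or a longer chain carrying the hydroxycarbamoyl group, would bring such a compound back inside the range of the assay.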